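The source may report more compounds than this note shows. Statements on the series, on what has been measured and on what is new or still open speak of the compounds shown alone.

Measured compounds:
compound 1 `COC(=O)Cn1cc(CO[C@H]2CC(=O)[C@@H]3OC[C@H]2O3)nn1` — 21300 nM
compound 2 `O=C1C[C@H](OCc2cn(-c3ccccc3)nn2)[C@H]2CO[C@@H]1O2` — 25200 nM
compound 3 `O=C1C[C@H](OCc2cc(-c3ccccc3)no2)[C@H]2CO[C@@H]1O2` — 21900 nM

All three numbers come from a functional assay on MDA-MB-231 cells (Homo sapiens) for cytotoxicity, read by MTT assay, with a stated time of 48 h; a higher number here means a weaker inhibitor, a lower number a stronger inhibitor. In this assay compound 3 gives 21900 nM, and compound 1 gives 21300 nM; the two lie within the scatter of each other. Compound 2 gives 25200 nM, again within the scatter of compound 3. None of the three is separated from another beyond the scatter, so no ordering among them can be read.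

Among the measured compounds shown here, the only step between measured compounds is a 1.2-fold higher number from compound 1 to compound 2 (0.07 log units; within the scatter). That change sits on the five-membered ring of the shared core and left the number essentially where it was.

Compound 4 `O=C1C[C@H](OCc2cc(C3CCCCC3)no2)[C@H]2CO[C@@H]1O2` is not yet measured. It differs from compound 3 by cyclohexyl in place of phenyl on an aromatic carbon. For the measured compounds named here, no measured pair shows this particular swap, so the step from compound 1 to compound 2 is the nearest guide: a change of the group carried on the five-membered ring, with no movement beyond the scatter. On that basis no step beyond the scatter is expected in this assay, in either direction, and the estimated step is a 1.0-fold higher number from compound 3 to compound 4 (0.00 log units; within the scatter).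

Compound 4 is therefore expected to give about 22000 nM in this assay, with a plausible range from 9000 nM to 55000 nM.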

Compound 4, half-maximal inhibitory concentration: 15800 nM
Compound 4: the middle estimate sits 1.4-fold (0.14 log units) above what was measured, within the range that was stated.
By their numbers in this assay, from the lowest: compounds 4, 1, 3 and 2 (each within the scatter of the next).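

In this assay, cyclohexyl in place of phenyl, on an aromatic carbon of a five-membered aromatic ring with 1 nitrogen and 1 oxygen, gives a 1.4-fold lower number from compound 3 to compound 4 (0.14 log units; within the scatter). Among the compounds shown here, this is the first measured change on this carbon, as the earlier step lay on an aromatic nitrogen, and it shows that a six-membered non-aromatic ring of carbon only can replace the six-membered aromatic ring here without a step beyond the scatter. No measurement shown bears on why the two compounds read as they do.

Both groups compared at this position are made of carbon alone, so the compounds shown leave open whether an amine, a carboxylic acid or a longer alkyl chain on this carbon would move the number beyond the scatter. Also open is whether any change to the shared core itself, such as replacing its carbonyl with a hydroxyl, would separate a compound from the others, since none of the steps shown so far lies beyond the scatter.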